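Series notes: cyclopropylcarbonyl to (tert-butyl)carbamoyl on the azetidine

The source may hold more compounds than are shown below. What is called first, only, known or untested is meant among the compounds shown, and "the series" means these compounds.

Of the compounds shown here, three have so far been measured in a functional assay on MIA PaCa-2 cells (Homo sapiens) for inhibition, read by MTT assay, with a stated time of 3 days; a lower number here means a stronger inhibitor, a higher number a weaker inhibitor. Compound 1 `CCOC(=O)[C@@H]1CCC[C@H](S(=O)(=O)c2ccc(S(=O)(=O)N(CC)CC)cc2)C1` returns only a limit, > 10000 nM. Compound 3 `CCOC(=O)[C@H]1CCN(S(=O)(=O)c2ccc(S(=O)(=O)N(CC)CC)cc2)C1` likewise returns only a limit, > 10000 nM. Within the data shown here, compound 2 `CCN(CC)S(=O)(=O)c1ccc(S(=O)(=O)N2CCC[C@@H](C(=O)NC3CN(C(=O)C4CC4)C3)C2)cc1` is the single compound with a number, 3100 nM. Among the measured compounds shown here, its standing is thus defined solely against (the limit of > 10000 nM in this assay, at which 2 of the 3 values shown sit), beneath which it falls; because the two other values are limits, no step between measured compounds can be sized, and no direction can be taken from the measured set.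

Compound 4 `CCN(CC)S(=O)(=O)c1ccc(S(=O)(=O)N2CCC[C@@H](C(=O)NC3CN(C(=O)NC(C)(C)C)C3)C2)cc1` differs from compound 2 in one place: (tert-butyl)amino in place of cyclopropyl on a carbonyl carbon. The remainder of compound 2 is carried over unchanged. For the measured compounds named here, no measured pair shows what this change does, so the data give no ground for a directional expectation. The working expectation is that the step of a 1.0-fold lower number from compound 2 to compound 4 (0.01 log units; within the scatter) stays within the scatter, with either sign possible. Compound 4 is accordingly estimated at 3000 nM in this assay, with a range from 1000 nM to 10000 nM.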

Compound 4, half-maximal inhibitory concentration: 1400 nM
Compound 4: the middle estimate sits 2.1-fold (0.33 log units) above what was measured; the range from low to high includes it.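

Among these compounds, this is the first step that can be sized: in this assay, (tert-butyl)amino in place of cyclopropyl on a carbonyl carbon gives a 2.2-fold lower number from compound 2 to compound 4 (0.35 log units; beyond the scatter). The position therefore accepts an open group in place of a three-membered carbon ring, with a modest gain, but this single step changes the ring, the carbon count and the amide hydrogen together, and cannot separate them. Compound 2 and compound 4 are the only compounds with numbers, and the others stand at a limit: the limit of > 10000 nM in this assay, at which 2 of the 4 values shown sit.

On these data alone, whether tert-butoxy or methylamino on the same carbonyl carbon would follow this step remains open, and such groups could separate the nitrogen from the tert-butyl group. Steps involving compound 1 or compound 3 cannot be read.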